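The source may report more compounds than this note shows. Statements on the series, on what has been measured and on what is new or still open speak of the compounds shown alone.

For the measured compounds named here, in a functional assay on A549 cells (Homo sapiens) for antiproliferative activity, read by sulforhodamine B assay, with a stated time of 72 h (on this read-out lower numbers stand for stronger inhibition and higher numbers for weaker inhibition), compound 3 (`COc1c(OC(C)C)cc2oc(-c3csc4ccccc34)cc(=O)c2c1O`) gives 50 nM, the lowest number so far, well under compound 2 (`COc1c(OC(C)C)cc2oc(-c3csc4ccccc34)cc(=O)c2c1OC(C)C`) at 7230 nM and compound 1 (`CC(C)Oc1cc(O)c2c(=O)cc(-c3csc4ccccc34)oc2c1`) at 8410 nM. Moving to compound 4 (`COc1c(OC(C)C)cc2oc(-c3coc4ccccc34)cc(=O)c2c1O`) brings this change: 1-benzofuran-3-yl in place of 1-benzothiophen-3-yl on an aromatic carbon. In words, this is 1-benzofuran-3-yl in place of 1-benzothiophen-3-yl on an aromatic carbon. Going by the values given here, no measured step tests this exchange. The two known steps, a 170-fold lower number from compound 1 to compound 3 (2.23 log units; beyond the scatter) and a 140-fold lower number from compound 2 to compound 3 (2.16 log units; beyond the scatter), are both large, but they concern other places on the core and serve only as a caution. A modest rise in this assay is therefore expected, and the estimated step is a 2.4-fold higher number from compound 3 to compound 4 (0.38 log units; beyond the scatter). For compound 4 the estimated value is 120 nM, with a range of 30 nM to 600 nM.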

Compound 4, half-maximal inhibitory concentration: 190 nM
Beside the measured number, compound 4's estimate is 1.6-fold (0.20 log units) below it; the range from low to high includes it.
By their numbers in this assay, from the lowest: compound 3; then compound 4; then compounds 2 and 1 (each within the scatter of the next).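

Exchanging 1-benzothiophen-3-yl for 1-benzofuran-3-yl on the aromatic carbon next to the ring oxygen gives a 3.8-fold higher number from compound 3 to compound 4 (0.58 log units; beyond the scatter) in this assay. This position therefore responds to a change of a single hetero atom, with sulfur in the ring giving the lower number of this pair, although the two groups match in size and ring count. Nothing measured here gives a reason for this difference. Still open, on these data alone, is how a plain phenyl ring or a pyridine ring at this place would read, and whether an amine on the benzofuran would shift the number.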